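Methylsulfanyl in place of aminoamino: one paired comparison

A few compounds are considered here, and "the series" means these few. Any claim that something is new, unique, unknown or untested is made for them only; others in the source may bear on it.

Compound 2 `Cn1c(NN)nc(-c2cccs2)c(C#N)c1=O` and compound 3 `Cn1c(NN)nc(-c2ccccc2Cl)c(C#N)c1=O` carry the same aminoamino group on the same kind of position; the difference between their two cores is not broken down here. In a functional assay, with a stated time of 10 min (on this read-out lower numbers stand for stronger inhibition and higher numbers for weaker inhibition), compound 2 gives 53 ug/mL, and compound 3 gives 46 ug/mL; the two numbers lie within the scatter of one another, so no order is read from them. Compound 1 `CSc1nc(-c2cccs2)c(C#N)c(=O)n1C` is compound 2 after one change, (methylsulfanyl in place of aminoamino on an aromatic carbon). In this assay compound 1 gives 72 ug/mL, and the step of a 1.4-fold higher number from compound 2 to compound 1 (0.13 log units; within the scatter) is within the scatter: the exchange leaves the read-out essentially where it was.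

Compound 4 `CSc1nc(-c2ccccc2Cl)c(C#N)c(=O)n1C` has not yet been measured. It stands to compound 3 as compound 1 stands to compound 2, with the change (methylsulfanyl in place of aminoamino on an aromatic carbon). The surroundings of the place are not word for word the same: in compound 2 the position is meta to a thiophen-2-yl group (5 heavy atoms), in compound 3 it is meta to a group of 7 heavy atoms. The change is therefore the same kind of change, not the same, and it has been observed only once among the compounds shown.

Among the measured compounds shown here, a step of about the same size as the one already seen is expected, a 1.3-fold higher number from compound 3 to compound 4 (0.12 log units; within the scatter), resting on the single pair a 1.4-fold higher number from compound 2 to compound 1 (0.13 log units; within the scatter). Compound 4 is accordingly expected to give 60 ug/mL in this assay, estimated between 35 ug/mL and 110 ug/mL.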

Compound 4, half-maximal inhibitory concentration: 67 ug/mL
Estimate against measurement, compound 4: 1.1-fold (0.05 log units) below, within the range that was stated.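

On the core of compound 3, the exchange of aminoamino for methylsulfanyl in this assay gives a 1.5-fold higher number from compound 3 to compound 4 (0.16 log units; within the scatter), so here too it leaves the read-out essentially where it was. Carried from the core of compound 2 to the core of compound 3, which differ in the thiophen-2-yl group and the group of 7 heavy atoms, the exchange behaves alike on both, and no difference can be read from the two steps: the same change on two cores in this assay, a 1.4-fold higher number (0.13 log units; within the scatter) from compound 2 to compound 1 and a 1.5-fold higher number (0.16 log units; within the scatter) from compound 3 to compound 4, 1.1-fold (0.03 log units) apart, within the scatter of two such steps This shows that the exchange was tolerated on both cores in this one read-out, but with both steps inside the scatter it gives no measurable effect to transfer, and two cores do not establish a rule for the series or show which, if any, of the features that differ under the exchange bear on the read-out.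

The compounds shown leave open whether any group in this place can move the read-out beyond the scatter, for instance a simple amine, a methoxy group, a carboxylic acid or a longer chain on the sulfur. They also leave open whether the same exchange stays this small on a core carrying some other group in place of the thiophen-2-yl group or the group of 7 heavy atoms.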